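Cathepsin S nitriles: a P1 substituent on the aminoacetonitrile

The source may hold more compounds than are shown below. What is called first, only, known or untested is meant among the compounds shown, and "the series" means these compounds.

Measured compounds:
compound 1 `CC(C)C[C@H](NC(=O)N1CCOCC1)C(=O)NCC#N`, 124 nM
compound 2 `CC(C)C[C@](C)(NC(=O)N1CCOCC1)C(=O)N[C@H](C#N)CCc1ccccc1`, 76000 nM

For the measured compounds named here, in an assay for inhibition of cathepsin S (Homo sapiens) (a lower number here means a stronger inhibitor, a higher number a weaker inhibitor), compound 1 gives 124 nM, the lower of the two numbers measured so far. Going by the values given here, compound 2 gives 76000 nM, a gap well beyond the usual scatter; compound 2 differs from compound 1 in more than one place, so its weak result cannot be tied to any single change, and no single-change step between measured compounds exists in this set.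

The next compound is compound 3 `Cc1ccccc1COC[C@@H](C#N)NC(=O)[C@H](CC(C)C)NC(=O)N1CCOCC1`, which keeps the core of compound 1 and carries ((2-methylbenzyl)oxy)methyl in place of hydrogen on a saturated chain carbon bound to an amide-type nitrogen and a triple-bonded carbon. Nothing measured here speaks directly to this change. The expectation is nonetheless for a moderate gain in this assay from compound 1 to compound 3, of about a 4.1-fold lower number from compound 1 to compound 3 (0.62 log units; beyond the scatter), since the substituent that enters is not of the kind that made compound 2 so weak; a result within the scatter of compound 1 would not be surprising. Compound 3 is estimated at 30 nM, with a plausible range from 5 nM to 200 nM.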

Compound 3, half-maximal inhibitory concentration: 19 nM
The estimate for compound 3 lay 1.6-fold (0.20 log units) above the measured number; the range from low to high includes it.
By their numbers in this assay, from the lowest: compound 3; then compound 1; then compound 2.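

In this assay, for the compounds shown here, ((2-methylbenzyl)oxy)methyl in place of hydrogen gives a 6.5-fold lower number from compound 1 to compound 3 (0.81 log units; beyond the scatter), the first single-change step and a modest one. Going by these compounds alone, it shows that the saturated chain carbon bound to an amide-type nitrogen and a triple-bonded carbon can carry a substituent with a six-membered aromatic ring of carbon only, with a lower number rather than a loss, a reading that the earlier compounds could not give for this position. No measurement here accounts for the size of this step, and the gain cannot be assigned to any part of the substituent.

A single substituent defines no trend, and the contributions of the ether oxygen, the aromatic ring and its methyl group remain unseparated. Going by these compounds, it remains open whether an unsubstituted benzyloxymethyl group, a simple methoxymethyl group or an aminomethyl group at the same carbon would keep the lower number, and what the opposite configuration at that carbon would do.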